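The compounds below may be only part of what the source reports. "The series", "measured", "known", "first", "only" and "open" are said of these compounds alone.

Compound 1 `Nc1nc(N)c2cc(CSC(=S)N3CCN(c4ccc(O)cc4)CC3)ccc2n1`: 5090 nM
Compound 2 `Cc1ccc(N2CCN(C(=S)SCc3ccc4nc(N)nc(N)c4c3)CC2)cc1`: 2480 nM
Compound 3 `Nc1nc(N)c2cc(CSC(=S)N3CCN(c4ccc(F)cc4F)CC3)ccc2n1`: 3670 nM

These values come from a functional assay on MCF7 cells (Homo sapiens) for antiproliferative activity, read by MTT assay, with a stated time of 72 h; a higher number here means a weaker inhibitor, a lower number a stronger inhibitor. Compound 3, at 3670 nM, cannot be told apart from the other two, with a 1.4-fold lower number from compound 1 to compound 3 (0.14 log units; within the scatter) and a 1.5-fold higher number from compound 2 to compound 3 (0.17 log units; within the scatter). Compound 4 `Nc1nc(N)c2cc(CSC(=S)N3CCN(c4ccccn4)CC3)ccc2n1` has pyridin-2-yl in place of 2,4-difluorophenyl on an amine nitrogen in a ring. Three measured steps change this same group. The largest, a 2.1-fold lower number from compound 1 to compound 2 (0.31 log units; beyond the scatter), is modest, and the other two stay within the scatter. For the measured compounds named here, no measured compound carries pyridin-2-yl, so the data leave this estimate loose. The step expected in this assay is a 1.0-fold higher number from compound 3 to compound 4 (0.02 log units; within the scatter), nothing beyond the scatter. Compound 4 is estimated at 3800 nM, with an expected range of 1700 nM to 8500 nM.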

Compound 4, half-maximal inhibitory concentration: 5110 nM
Compound 4: middle estimate off by 1.3-fold (0.13 log units), on the low side; low and high end bracket the measured number.
By their numbers in this assay, from the lowest: compounds 2, 3, 1 and 4 (each within the scatter of the next, the first and the last beyond it).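

In this assay, pyridin-2-yl on this piperazine-type amine nitrogen cannot be told apart from two phenyl groups, with a 1.4-fold higher number from compound 3 to compound 4 (0.14 log units; within the scatter) and a 1.0-fold higher number from compound 1 to compound 4 (0.00 log units; within the scatter). Against 4-methylphenyl, the change gives a modest loss, with a 2.1-fold higher number from compound 2 to compound 4 (0.31 log units; beyond the scatter), so an aromatic ring holding a nitrogen sits level with 4-hydroxyphenyl here. Nothing available explains these small differences. From the compounds shown here alone, whether pyridin-3-yl or pyridin-4-yl would read the same remains open, as does the effect of a carboxylic acid or an amine on the aromatic ring.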